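Methyl on the Saturated Ring: Expectation for Compound 3

A few compounds are considered here, and "the series" means these few. Any claim that something is new, unique, unknown or untested is made for them only; others in the source may bear on it.

Of the two numbers shown in a functional assay on P388 cells (Mus musculus) for inhibition, with a stated time of 48 h, tested at 0.1 ug/mL (on this read-out higher numbers stand for a stronger effect at the one concentration tested and lower numbers for a weaker effect), compound 1 `C=C1C(=O)O[C@H]2CCCCC[C@@H]12` holds the smaller, giving 9%, though it sits within the scatter of the other. Compound 2 `C=C1C(=O)O[C@H]2[C@@H](O)CCCC[C@@H]12` in this assay gives 11%, and the step of a number 2 percentage points higher from compound 1 to compound 2 (within the scatter), hydroxy in place of hydrogen on a saturated ring carbon, lies within the scatter. Compound 3 `C=C1C(=O)O[C@H]2CC[C@H](C)CC[C@@H]12` differs from compound 1 by methyl in place of hydrogen on a saturated ring carbon. Among the measured compounds shown here, no measured step carries a methyl, and the only change on a saturated ring carbon, from compound 1 to compound 2, stayed within the scatter. Compound 3 is therefore expected to show a number 1 percentage points higher from compound 1 to compound 3 (within the scatter), nothing beyond the scatter. The estimated value for compound 3 is 10%, between 0% and 25%.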

Compound 3, a percentage reported as activity, at one concentration (the size of the read-out at that concentration, not a potency): 15%
For compound 3 the middle estimate is 5 percentage points below the measured one; the range from low to high includes it.
By their numbers in this assay, from the lowest: compounds 1, 2 and 3 (each within the scatter of the next).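

Among the compounds shown here, compound 3 gives the first reading for a methyl on the seven-membered ring, three ring bonds from two ring atoms that each bear a fused ring: in this assay the step is a number 6 percentage points higher from compound 1 to compound 3 (within the scatter) and so does not separate the two compounds. Methyl at this position thus leaves the read-out within the scatter of the core of compound 1. No evidence bears on this result.

On these data alone, whether a longer chain, an amine or a carboxylic acid at this position would go beyond the scatter remains open.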